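The source may report more compounds than this note shows. Statements on the series, on what has been measured and on what is new or still open speak of the compounds shown alone.

In a functional assay on HeLa cells (Homo sapiens) for antiproliferative activity, read by MTT assay, with a stated time of 72 h (a higher number here means a weaker inhibitor, a lower number a stronger inhibitor), compound 1 (`COc1cccc(N2C(=O)COc3ccc(-c4cnc(Cl)c(NS(=O)(=O)c5ccc(F)cc5)c4)cc32)c1`) gives > 40000 nM, which is a limit. Compound 2 (`COc1cccc(N2C(=O)COc3ccc(-c4cnc(OC)c(NS(=O)(=O)c5ccc(F)cc5)c4)cc32)c1`) gives > 40000 nM, also a limit, so it has no readable position on the numbers. Compound 3 (`COc1cccc(N2C(=O)COc3ccc(-c4ccc(O)cc4)cc32)c1`) gives > 40000 nM, again a limit. The three stand together: the limit of > 40000 nM in this assay, at which 3 of the 3 values shown sit. Going by the values given here, the only measured step is a step that the two limits leave unreadable from compound 1 to compound 2, and it offers no size to carry over. Compound 4 (`COc1ccc(N2C(=O)COc3ccc(-c4cnc(OC)c(NS(=O)(=O)c5ccc(F)cc5)c4)cc32)cc1`) differs from compound 2 by 4-methoxyphenyl in place of 3-methoxyphenyl on an amide-type nitrogen in a ring. Among the compounds with values here, no measured step touches this place. The expectation therefore rests on compound 2 at > 40000 nM, a limit, and no step beyond the scatter is expected in this assay. The expected step is a number no higher from compound 2 to compound 4 (the limit leaves the size open). Compound 4 is estimated at 40000 nM, with an expected range of 15000 nM to 100000 nM.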

Compound 4, half-maximal inhibitory concentration: 1220 nM
For compound 4 the middle estimate is 33-fold (1.52 log units) above the measured one; measured number outside the range, below it.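

In this assay, 4-methoxyphenyl in place of 3-methoxyphenyl on the amide-type nitrogen gives an at least 32-fold lower number from compound 2 to compound 4 (1.51 log units; beyond the scatter). This position therefore matters: two groups with the same atoms, joined differently, separate a readable number from the limit. Compound 1, compound 2 and compound 3 remain without a readable number: the limit of > 40000 nM in this assay, at which 3 of the 4 values shown sit.

Open, on these data alone, is whether other groups on that nitrogen, such as 4-aminophenyl or 4-carboxyphenyl, also give a readable number. Also open, as far as these compounds go, is whether 4-methoxyphenyl gives one with chloro in place of methoxy on the aromatic carbon.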